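This account rests on a few compounds, and the source may have more. Where it says the series, first, only, none or still open, it means among the compounds named here.

Working notes on the series. Compound 3 `CCC(=O)/N=C(\N)NCCCc1c[nH]cn1` carries the shared core with a propanoyl group. In an in vitro assay on Sf9 cells for agonist activity at histamine H2 receptor (Homo sapiens), read by scintillation counting (on this read-out lower numbers stand for an effect already at smaller amounts and higher numbers for an effect only at larger amounts of compound), compound 3 gives 372 nM, the highest of the three numbers to hand. Compound 1 `N/C(=N\C(=O)c1cc2ccccc2[nH]1)NCCCc1c[nH]cn1` gives 288 nM, within the scatter of compound 3. Compound 2 `N/C(=N\C(=O)CCc1c[nH]c2ccccc12)NCCCc1c[nH]cn1` gives 81.3 nM, beyond the scatter below compound 3. Compound 4 `CCCC(=O)/N=C(\N)NCCCc1c[nH]cn1` differs from compound 3 by methyl in place of hydrogen on a saturated chain carbon, two bonds along the chain from a carbonyl carbon. Within the data shown here, no pair of measured compounds differing in one place is at hand, so the size of this change cannot be read from the data; compound 1 and compound 2 show only that the two other variants at this position gave no higher numbers. For compound 4 in this assay a step of a 1.4-fold lower number from compound 3 to compound 4 (0.16 log units; within the scatter) is expected, likely not beyond the scatter. The estimate for compound 4 is 260 nM, ranging from 110 nM to 620 nM.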

Compound 4, half-maximal effective concentration: 141 nM
The estimate for compound 4 lay 1.8-fold (0.27 log units) above the measured number, within the range that was stated.
By their numbers in this assay, from the lowest: compounds 2 and 4 (each within the scatter of the next); then compounds 1 and 3 (each within the scatter of the next).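

Among these compounds, this is the first single-place comparison, and it gives the change a size: in this assay, methyl in place of hydrogen on a saturated chain carbon, two bonds along the chain from a carbonyl carbon, gives a 2.6-fold lower number from compound 3 to compound 4 (0.42 log units; beyond the scatter). The position therefore responds to a single added carbon, going from propanoyl to propylcarbonyl. Nothing at hand explains the step.

A single step leaves open whether a longer chain would lower the number further or reverse the change. As far as these compounds go, it is also open how an amine or a carboxylic acid at this carbon would read.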